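This account rests on a few compounds, and the source may have more. Where it says the series, first, only, none or still open, it means among the compounds named here.

Measured so far:
compound 1 `O=c1[nH]/c(=N\OCc2ccccc2)ccn1[C@@H]1O[C@H](COP(=O)(O)OP(=O)(O)OP(=O)(O)OP(=O)(O)O[C@H]2O[C@H](CO)[C@@H](O)[C@H](F)[C@H]2O)[C@@H](O)[C@H]1O` — 670 nM
compound 2 `CC(C)(C)O/N=c1/ccn([C@@H]2O[C@H](COP(=O)(O)OP(=O)(O)OP(=O)(O)O)[C@@H](O)[C@H]2O)c(=O)[nH]1` — 2110 nM

In an in vitro functional assay on 1321-N1 cells for agonist activity at P2Y purinoceptor 4 (Homo sapiens), read by scintillation proximity assay and inositol phosphate accumulation, with a stated time of 30 min (a lower number here means that less compound is needed, a higher number that more compound is needed for the effect), compound 1 gives 670 nM and compound 2 gives 2110 nM. Compound 2 stands highest of the two numbers; the gap to compound 1 lies beyond the scatter, but the two differ in more than one place, so no single-point step can be read from them. Compound 3 `O=c1[nH]/c(=N\OCCc2ccccc2)ccn1[C@@H]1O[C@H](COP(=O)(O)OP(=O)(O)OP(=O)(O)O)[C@@H](O)[C@H]1O` differs from compound 2 in one place: phenethyl in place of tert-butyl on an oxygen. Nothing measured isolates this change, and compound 1 only shows that a lower number is reachable in this assay. The step from compound 2 to compound 3 is expected to be modest, toward a lower number, a 2.3-fold lower number from compound 2 to compound 3 (0.37 log units; beyond the scatter). Compound 3 is estimated at 900 nM, within 300 nM to 2700 nM.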

Compound 3, half-maximal effective concentration: 73 nM
Estimate against measurement, compound 3: 12-fold (1.09 log units) above; measured number outside the range, below it.
By their numbers in this assay, from the lowest: compound 3; then compound 1; then compound 2.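

Among these compounds, on the oxygen whose other neighbour is the double-bonded nitrogen, phenethyl in place of tert-butyl gives a 29-fold lower number from compound 2 to compound 3 (1.46 log units; beyond the scatter) in this assay and provides the first single-place step. This position is therefore sensitive to the group it carries, and the low end of the series is reached here with phenethyl on the shared core. Nothing available accounts for the size of this step.

Open, from the compounds shown here alone, is whether the ring or the chain carries the step, since only these two groups are compared on this core. A phenylpropyl or cyclohexylethyl group on the same oxygen would help separate the two.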